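The source may hold more compounds than are shown below. What is called first, only, known or untested is meant among the compounds shown, and "the series" means these compounds.

Working notes on the series. For the measured compounds named here, compound 3 `CC1(C)[C@H]2CC[C@]1(C)N(Cc1cn(-c3cccc(Br)c3)nn1)C(=O)C2` in a functional assay on SGC-7901 cells (Homo sapiens) for inhibition, read by MTT assay, with a stated time of 24 h (on this read-out higher numbers stand for weaker inhibition and lower numbers for stronger inhibition), gives 120 nM, the lowest of the three numbers so far. Compound 1 `COc1ccc(-n2cc(CN3C(=O)C[C@@H]4CC[C@@]3(C)C4(C)C)nn2)cc1` in this assay gives 480 nM, and compound 2 `CC1(C)[C@H]2CC[C@]1(C)N(Cc1cn(-c3ccc(F)cc3)nn1)C(=O)C2` gives 500 nM; the steps of a 4.0-fold lower number from compound 1 to compound 3 (0.60 log units; beyond the scatter) and a 4.2-fold lower number from compound 2 to compound 3 (0.62 log units; beyond the scatter) both move the number down, and the step of a 1.0-fold higher number from compound 1 to compound 2 (0.02 log units; within the scatter) is flat. Compound 4 `CC1(C)[C@H]2CC[C@]1(C)N(Cc1cn(-c3ccc(O)cc3)nn1)C(=O)C2` differs from compound 3 by 4-hydroxyphenyl in place of 3-bromophenyl on an aromatic nitrogen. No hydroxyphenyl has been measured, but compound 1 and compound 2 both carry a 4-substituted phenyl on the aromatic nitrogen and sit well above compound 3, so this change is expected to undo the gain, giving roughly a 3.8-fold higher number from compound 3 to compound 4 (0.57 log units; beyond the scatter). Compound 4 is therefore expected near 450 nM, within 180 nM to 1200 nM.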

Compound 4, half-maximal inhibitory concentration: 330 nM
For compound 4 the middle estimate is 1.4-fold (0.13 log units) above the measured one; the measured number falls inside the stated range.
By their numbers in this assay, from the lowest: compound 3; then compounds 4, 1 and 2 (each within the scatter of the next).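

In this assay, 4-hydroxyphenyl on the aromatic nitrogen gives up part of what 3-bromophenyl holds, with a 2.8-fold higher number from compound 3 to compound 4 (0.44 log units; beyond the scatter), while a 1.5-fold lower number from compound 2 to compound 4 (0.18 log units; within the scatter) and a 1.5-fold lower number from compound 1 to compound 4 (0.16 log units; within the scatter) leave compound 4 within the scatter of both other 4-substituted phenyls. Hydroxy, fluoro and methoxy thus read alike here even with the added hydrogen-bond donor, and only 3-bromophenyl stands apart among the four compounds. No evidence on hand bears on this result.

From the compounds shown here alone, whether the bromine or its place on the ring carries the difference stays open, and 4-bromophenyl and 3-hydroxyphenyl would separate the two. Going by these compounds, how an amine or a carboxylic acid on the phenyl ring would read also stays open.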